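A few compounds are considered here, and "the series" means these few. Any claim that something is new, unique, unknown or untested is made for them only; others in the source may bear on it.

Measured in a physicochemical assay for solubility, read by HPLC, in simulated intestinal fluid, with a stated time of 16 h, at pH 6.5, tested at 2.5 mg/mL; on this read-out lower numbers stand for lower solubility and higher numbers for higher solubility:

- compound 1 `CC[C@@]1(c2ccccc2)COc2c(C(=O)NC)cc(C(=O)N[C@H]3[C@@H]4COC[C@@H]43)cc21`: 93 ug/mL
- compound 2 `CNC(=O)c1cc(C(=O)N[C@H]2[C@@H]3COC[C@@H]32)cc2c1OC[C@@]2(C)c1ccccc1`: 80 ug/mL
- compound 3 `CNC(=O)c1cc(C(=O)N[C@H]2C[C@@H]2C)cc2c1OC[C@@]2(CO)c1ccccc1`: > 1000 ug/mL

Compound 3 gives a limit of the assay, not a number. Within the data shown here, that leaves only two true numbers, and they cannot be told apart: a 1.2-fold lower number from compound 1 to compound 2 (0.07 log units; within the scatter). Compound 2 therefore stands level with compound 1, its nearest neighbour on the numbers.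

Compound 4 `CNC(=O)c1cc(C(=O)N[C@H]2[C@@H]3C[C@@H](O)C[C@@H]32)cc2c1OC[C@@]2(C)c1ccccc1` has not yet been measured. It differs from compound 2 on an amide-type nitrogen: a group of 7 heavy atoms (6 carbon, 1 oxygen; one three-membered non-aromatic ring of carbon only, one five-membered non-aromatic ring of carbon only) in place of a group of 6 heavy atoms (5 carbon, 1 oxygen; one three-membered non-aromatic ring of carbon only, one five-membered non-aromatic ring with 1 hetero atom), on an amide-type nitrogen. Among the measured compounds shown here, the one measured step, a 1.2-fold lower number from compound 1 to compound 2 (0.07 log units; within the scatter), concerns a saturated chain carbon and not this amide-type nitrogen, so it gives no size for the new change. For the measured compounds named here, with compound 2 at 80 ug/mL as the starting point, no step clearly beyond the scatter is expected in this assay, though the expectation leans slightly upward. The expected change is a 1.6-fold higher number from compound 2 to compound 4 (0.21 log units; within the scatter), and this estimate is loosely held. Compound 4 is estimated at 130 ug/mL, with an expected range of 45 ug/mL to 450 ug/mL.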

Compound 4, solubility: > 1000 ug/mL
Compound 4: no number, only a limit; the forecaster's own chance of this, stated with the estimate: 5%; middle value at least 7.6-fold (0.88 log units) away from the limit.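

In this assay compound 4 gives > 1000 ug/mL, which is a limit of the assay and not a number. Even so, the change on the amide-type nitrogen is the first single change here to go beyond the scatter, with an at least 12-fold higher number from compound 2 to compound 4 (1.09 log units; beyond the scatter), whereas the earlier step on a saturated chain carbon stayed within it. The entering group counts 1 hydrogen-bond donor where the leaving group counts 0, and its five-membered ring is of carbon only, yet the true size of the step stays hidden: the limit of > 1000 ug/mL in this assay, at which 2 of the 4 values shown sit.

The compounds shown cannot tell whether the new donor or the loss of the ring hetero atom carries the step. Going by these compounds, whether an amine or a carboxylic acid on the same five-membered carbon ring would behave alike also stays open.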